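Moving a Methoxy Group on an Amide Nitrogen

The compounds below may be only part of what the source reports. "The series", "measured", "known", "first", "only" and "open" are said of these compounds alone.

Of the compounds shown here, two have been measured in a functional assay on HCT-15 cells (Homo sapiens) for inhibition, read by sulforhodamine B assay, with a stated time of 48 h; a higher number here means a weaker inhibitor of growth, a lower number a stronger inhibitor of growth. Compound 1 `O=C(Nc1ccc(O)cc1)C1NCCc2ccccc21` gives 5730 nM. Compound 2 `COc1ccc(NC(=O)C2c3ccccc3CCN2C(=O)c2ccc(Cl)cc2)cc1` gives 6080 nM; of the two numbers this one is nearest to compound 1, and the gap between them lies within the usual scatter, so the two cannot be told apart. Compound 3 `COc1ccccc1NC(=O)C1c2ccccc2CCN1C(=O)c1ccc(Cl)cc1` has the same atoms as compound 2 joined differently: 2-methoxyphenyl in place of 4-methoxyphenyl on an amide-type nitrogen. For the measured compounds named here, no measured pair shows what such a swap does here, so in this assay the expectation is a step of no more than the scatter, in no fixed direction, with a modest shift either way still possible. For compound 3 the estimated value is 6000 nM, expected to fall between 2500 nM and 15000 nM. The step this estimate means is a 1.0-fold lower number from compound 2 to compound 3 (0.01 log units; within the scatter).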

Compound 3, concentration for 50% growth inhibition: 1740 nM
The estimate for compound 3 lay 3.4-fold (0.54 log units) above the measured number; measured number below the stated range.
By their numbers in this assay, from the lowest: compound 3; then compounds 1 and 2 (each within the scatter of the next).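

In this assay the swap of 4-methoxyphenyl for 2-methoxyphenyl on the amide-type nitrogen gives a 3.5-fold lower number from compound 2 to compound 3 (0.54 log units; beyond the scatter), the first step available here between compounds that differ in one place. It shows that this position can respond to where the methoxy group sits, even though the same atoms are present and the counts of hydrogen-bond donors and acceptors stay the same. Nothing available explains why this rearrangement changes the number.

Still open, going by these compounds, is whether an ethoxy group, an amine or a carboxylic acid in place of the methoxy group would give a similar number. Also open, on these data alone, is whether the same swap would give a comparable step on the core of compound 1.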